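Amide aryl swap on a weakly cytotoxic piperazine series

This account rests on a few compounds, and the source may have more. Where it says the series, first, only, none or still open, it means among the compounds named here.

Compound 1 `Cc1ccc(F)cc1NC(=O)CN1CCN(c2nnc(Cc3ccccc3)c3ccccc23)CC1`: 171000 nM
Compound 2 `COc1ccc(NC(=O)CN2CCN(c3nnc(Cc4ccccc4)c4ccccc34)CC2)cc1OC`: 145000 nM
Compound 3 `Cc1ccc(NC(=O)CN2CCN(c3nnc(Cc4ccccc4)c4ccccc34)CC2)c(C)c1`: "not active" (no number reported)
Compound 4 `O=C(CN1CCN(c2nnc(Cc3ccccc3)c3ccccc23)CC1)Nc1ccc(F)c(C(F)(F)F)c1`: not yet measured

In a functional assay on HT-29 cells (Homo sapiens) for cytotoxicity, read by MTT assay, with a stated time of 72 h (on this read-out higher numbers stand for weaker inhibition and lower numbers for stronger inhibition), compound 1 gives 171000 nM and compound 2 gives 145000 nM; the step of a 1.2-fold lower number from compound 1 to compound 2 (0.07 log units; within the scatter) shows that exchanging the aryl group on the amide-type nitrogen leaves the read-out unchanged within the scatter. Compound 3 is reported only as not active, with no single number, so it stands outside the measured range of the other two.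

Compound 4 differs from compound 3 by 4-fluoro-3-(trifluoromethyl)phenyl in place of 2,4-dimethylphenyl on an amide-type nitrogen. Going by the values given here, no measured step covers this exact pair; the one measured step, from compound 1 to compound 2, was within the scatter, and compound 3 itself gave no number. Nothing here points to a shift beyond the scatter in either direction. Compound 4 is therefore expected near the weak values of compound 1 and compound 2, estimated at 160000 nM with a range of 50000 nM to 500000 nM, and a real chance that only a limit is reported.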

Compound 4, half-maximal inhibitory concentration: 4590 nM
Beside the measured number, compound 4's estimate is 35-fold (1.54 log units) above it; measured number outside the range, below it.
By their numbers in this assay, from the lowest: compound 4; then compounds 2 and 1 (each within the scatter of the next).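

In this assay, the aryl group on the amide-type nitrogen proves able to move the read-out: the change to 4-fluoro-3-(trifluoromethyl)phenyl gives a 32-fold lower number from compound 2 to compound 4 (1.50 log units; beyond the scatter) and a 37-fold lower number from compound 1 to compound 4 (1.57 log units; beyond the scatter), whereas the earlier exchange gave only a 1.2-fold lower number from compound 1 to compound 2 (0.07 log units; within the scatter). Steps to compound 3 cannot be read, as it has no number. No measurement bearing on the cause of these steps is available.

From the compounds shown here alone, whether the fluorine or the trifluoromethyl carries the gain remains open. So does the reading of a nitrile or a carboxylic acid on this aryl ring.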